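Oxime ether to oxime carbamate on the diaryl sulfide scaffold

The compounds below may be only part of what the source reports. "The series", "measured", "known", "first", "only" and "open" are said of these compounds alone.

Measured so far:
compound 1, `C/C(=N\OC(C)C)c1ccc(Sc2cc(F)cc(C3CCOCC3)c2)cc1`: 920 nM
compound 2, `COC1(c2cc(F)cc(Sc3ccc4c(c3)OCC/C4=N\O)c2)CCOCC1`: 50 nM

Both were run in a functional assay (blood) for inhibition, with Homo sapiens as the target; on this read-out higher numbers stand for weaker inhibition and lower numbers for stronger inhibition. Compound 1 gives the higher of the two numbers, 920 nM; compound 2 sits at 50 nM, a gap well beyond the usual scatter. The two compounds differ in several places at once, so the pair says nothing about any single change.

Compound 3 `C/C(=N\OC(=O)N(C)C)c1ccc(Sc2cc(F)cc(C3CCOCC3)c2)cc1` is not yet measured. It differs from compound 1 in one place: dimethylcarbamoyl in place of isopropyl on an oxygen. The shared core is untouched; only the group on the oxygen whose other neighbour is a double-bonded nitrogen is exchanged.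

Among the measured compounds shown here, no measured pair isolates this exchange, so the direction of the step rests on nothing but compound 1 itself. The step is expected to be small, within or just beyond the scatter, in either direction: a 1.1-fold higher number from compound 1 to compound 3 (0.04 log units; within the scatter). Compound 3 is therefore estimated at 1000 nM, with a range from 350 nM to 3000 nM.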

Compound 3, half-maximal inhibitory concentration: 2610 nM
Estimate against measurement, compound 3: 2.6-fold (0.42 log units) below; the measured number falls inside the stated range.
By their numbers in this assay, from the lowest: compound 2; then compound 1; then compound 3.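

On the oxygen whose other neighbour is a double-bonded nitrogen, the exchange of isopropyl for dimethylcarbamoyl has a readable effect in this assay: a 2.8-fold higher number from compound 1 to compound 3 (0.45 log units; beyond the scatter), toward weaker inhibition and the only single-place read at this position. The entering group carries more heavy atoms and a hydrogen-bond acceptor, and this one pair cannot show which of these differences, if any, goes with the step. No measurement at hand bears on the reason for the step.

Still open, on these data alone, is how other groups on this oxygen would read, such as a methyl, a longer alkyl chain, an acetyl or a morpholine-derived carbamoyl. Also open, as far as these compounds go, is whether the same exchange would read alike on the core of compound 2, which differs from compound 1 in several places.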